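A few compounds are considered here, and "the series" means these few. Any claim that something is new, unique, unknown or untested is made for them only; others in the source may bear on it.

In a functional assay for inhibition, with Homo sapiens as the target (a lower number here means a stronger inhibitor, a higher number a weaker inhibitor), compound 1 `O=C(O)CCNC(=O)c1cc2cc(OCC3CCNCC3)ccc2[nH]1` gives 1000 nM. Going by the values given here, the only other measured compound, compound 2 `O=C(O)CC(NC(=O)c1cc2cc(OCC3CCNCC3)ccc2[nH]1)c1cccnc1`, gives 810 nM, so the two stand level. The measured step is a 1.2-fold lower number from compound 1 to compound 2 (0.09 log units; within the scatter).

Compound 3 `O=C(NC[C@H](NS(=O)(=O)c1cccnc1)C(=O)O)c1cc2cc(OCC3CCNCC3)ccc2[nH]1` has not yet been measured. Its difference from compound 1 is ((pyridin-3-yl)sulfonyl)amino in place of hydrogen on a saturated chain carbon bound to a carbonyl carbon and a saturated chain carbon. In words, ((pyridin-3-yl)sulfonyl)amino stands in place of hydrogen on a saturated chain carbon bound to a carbonyl carbon and a saturated chain carbon.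

Among the compounds with values here, only one measured step bears on this change, and only loosely. Compound 2 also gains a pyridin-3-yl group, but on a saturated chain carbon bound to an amide-type nitrogen, and without the sulfonyl and amino parts. That change gave a 1.2-fold lower number from compound 1 to compound 2 (0.09 log units; within the scatter), so it offers no measured support for a large shift. One step at another carbon cannot exclude such a shift either. A moderately lower number in this assay is therefore expected, with wide uncertainty. The expected change is a 3.3-fold lower number from compound 1 to compound 3 (0.52 log units; beyond the scatter). For compound 3 the estimated value is 300 nM, with an expected range of 40 nM to 1500 nM.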

Compound 3, half-maximal inhibitory concentration: 12 nM
Beside the measured number, compound 3's estimate is 25-fold (1.40 log units) above it; the whole stated range lies above it.
By their numbers in this assay, from the lowest: compound 3; then compounds 2 and 1 (each within the scatter of the next).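

In this assay, the saturated chain carbon bound to a carbonyl carbon and a saturated chain carbon turns out to be a place where one change can move the number a long way: ((pyridin-3-yl)sulfonyl)amino in place of hydrogen gives an 83-fold lower number from compound 1 to compound 3 (1.92 log units; beyond the scatter) on the same core. The earlier pair gave no sign of this, as pyridin-3-yl on a saturated chain carbon bound to an amide-type nitrogen gave only a 1.2-fold lower number from compound 1 to compound 2 (0.09 log units; within the scatter), and these two steps together show that a pyridine ring added to this chain does not by itself guarantee a large shift. Nothing available explains why the number falls so far in compound 3.

From the compounds shown here alone, this one step brings in the amino nitrogen, the sulfonyl and the pyridine ring all at once, and their separate shares remain unknown; a plain amino group or an acetylamino group at this carbon, or phenylsulfonylamino with a benzene ring in place of the pyridine, would help to separate them. Also open, going by these compounds, is how the mirror-image arrangement at this carbon, or a longer chain carrying the carboxylic acid, would compare.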